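The source may hold more compounds than are shown below. What is called first, only, known or untested is meant among the compounds shown, and "the series" means these compounds.

Compound 1, `COc1cc(NC(C)CCCN2C(=O)CN(C(=O)[C@H](N)CCSC)C2(C)C)c2ncccc2c1`: in a physicochemical assay for lipophilicity, measured as octanol-water partition (on this read-out lower numbers stand for lower lipophilicity and higher numbers for higher lipophilicity), compound 1 gives 2.94.
Compound 2, `COc1cc(NC(C)CCCN2C(=O)CN(C(=O)[C@@H](C)N)C2(C)C)c2ncccc2c1`: in this assay compound 2 gives 2.49.

Of the two numbers in this assay, compound 2 stands lowest; its nearest neighbour is compound 1, whose value is higher by a step beyond the scatter. That step, a number 0.45 log units lower from compound 1 to compound 2 (beyond the scatter), is the only measured one and it sits at the very place where the next change is made: hydrogen in place of (methylsulfanyl)methyl on a saturated chain carbon, two bonds along the chain from an amine nitrogen and a carbonyl carbon.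

Compound 3, `COc1cc(NC(C)CCCN2C(=O)CN(C(=O)[C@H](N)CC(C)C)C2(C)C)c2ncccc2c1`, has not yet been measured in this assay. It differs from compound 2 in one place: isopropyl in place of hydrogen on a saturated chain carbon, two bonds along the chain from an amine nitrogen and a carbonyl carbon. The step from compound 1 to compound 2 bears on this, since it removed a three-heavy-atom group at the same carbon and lowered the number modestly. Putting a group of the same heavy-atom count back in is expected to move this assay upward, by a step in the region of a number 0.71 log units higher from compound 2 to compound 3 (beyond the scatter). For compound 3 the expected value in this assay is therefore 3.2, with a range from 2.8 to 3.6.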

Compound 3, partition coefficient: 3.36
The estimate for compound 3 lay 0.16 log units below the measured number, and the stated range covers the measured number.
By their numbers in this assay, from the lowest: compound 2; then compound 1; then compound 3.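

Placing isopropyl on this saturated chain carbon, two bonds along the chain from an amine nitrogen and a carbonyl carbon, gives a number 0.87 log units higher from compound 2 to compound 3 (beyond the scatter) in this assay, a larger move than the one seen when (methylsulfanyl)methyl gave way to hydrogen at the same carbon. The two groups with the same heavy-atom count do not give the same number either: isopropyl in place of (methylsulfanyl)methyl gives a number 0.42 log units higher from compound 1 to compound 3 (beyond the scatter), so across these compounds the heavy-atom count of the group does not alone fix the value, and the identity of the group also matters. No accompanying measurement accounts for the gap between these two groups.

The compounds shown leave open where an unbranched chain such as n-butyl, or a ring-bearing group such as benzyl, would fall relative to isopropyl at this carbon. They also leave open how far the number would fall with a hydroxymethyl group, a carboxylic acid or a second amine at the same place, since only hydrogen and two groups without such atoms have been compared here.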